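Amide side-chain replacement: step from compound 2 to compound 3

The source may report more compounds than this note shows. Statements on the series, on what has been measured and on what is new or still open speak of the compounds shown alone.

Measured so far:
compound 1 `Cn1c(-c2ccc(NC(=O)CSc3nc4ccccc4o3)cc2)nc(-c2ccccc2)c1-c1ccccc1`: 76.3%
compound 2 `CN(C)/C=C/N1CCN(CC(=O)Nc2ccc(-c3nc(-c4ccccc4)c(-c4ccccc4)n3C)cc2)CC1`: 34.7%

In a functional assay on MCF7 cells (Homo sapiens) for cytotoxicity, read by MTT assay, with a stated time of 24 h, tested at 80 ug/mL (on this read-out lower numbers stand for a weaker effect and higher numbers for a stronger effect at the one concentration tested), compound 1 gives 76.3%, while compound 2 gives 34.7%. For the measured compounds named here, compound 2 stands lowest of the two numbers; its only neighbour is compound 1, and the step of a number 41.6 percentage points lower from compound 1 to compound 2 (beyond the scatter) is large and beyond the scatter.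

Compound 3 `Cn1c(-c2ccc(NC(=O)CN3CCN(Cc4ccccc4)CC3)cc2)nc(-c2ccccc2)c1-c1ccccc1` is the next member. It differs from compound 2 by benzyl in place of 2-(dimethylamino)ethenyl on an amine nitrogen in a ring.

Going by the values given here, only one measured step exists, the one from compound 1 to compound 2, and it swaps the whole group on the saturated chain carbon bound to the carbonyl carbon; it does not touch a group on the amine nitrogen in the ring. It shows that changes in this part of the molecule can move the read-out by a large amount, but it gives no direction for a change confined to the ring nitrogen. The expected step is therefore small and uncertain: compound 3 is expected to sit near compound 2, with a step of about a number 7.3 percentage points higher from compound 2 to compound 3 (within the scatter) in this assay, that is a change not clearly beyond the scatter.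

The estimate for compound 3 in this assay is 42%, within a range of 18% to 70%.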

Compound 3, a percentage reported as activity, at one concentration (the size of the read-out at that concentration, not a potency): 49.5%
Compound 3: middle estimate off by 7.5 percentage points, on the low side; the measured number falls inside the stated range.
By their numbers in this assay, from the lowest: compound 2; then compound 3; then compound 1.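

In this assay, a change confined to the amine nitrogen in the ring is enough to move the read-out: benzyl in place of 2-(dimethylamino)ethenyl gives a number 14.8 percentage points higher from compound 2 to compound 3 (beyond the scatter). The earlier step replaced the whole group on the saturated chain carbon, whereas here the six-membered non-aromatic ring with 2 nitrogen stays in place, so this position now has a measured effect of its own, modest in size and upward in direction. The swap changes several counted features at once, exchanging an open group of 5 heavy atoms with a double bond, a nitrogen and a hydrogen-bond acceptor for a carbon-only group of 7 heavy atoms with an aromatic ring, and no measurement here bears on why the read-out moves.

From the compounds shown here alone, a single step cannot separate these features, so it remains open whether the aromatic ring, the loss of the nitrogen or the added heavy atoms account for the difference. A methyl, a cyclohexylmethyl or a 2-phenylethyl group on the same ring nitrogen would help to separate them, and the series shown gives no value for any of these groups.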